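The source may hold more compounds than are shown below. What is called first, only, known or untested is meant among the compounds shown, and "the series" means these compounds.

Compound 1 `COc1cc(Cl)cc(-c2nn(-c3cccc(NC(=O)c4ccc(Cl)c(Cl)c4)c3)cc2-c2ccncc2)c1` gives 54.6% in a functional assay on MDA-MB-468 cells (Homo sapiens) for inhibition, read by sulforhodamine B assay, with a stated time of 48 h, tested at 10 uM; a lower number here means a stronger effect, a higher number a weaker effect of the compound at the concentration tested. Compound 2 `O=C(Nc1cccc(-n2cc(-c3ccncc3)c(-c3cc(O)cc(Cl)c3)n2)c1)Nc1ccc(Cl)c(C(F)(F)F)c1` gives 5.22% in this assay, and compound 3 `COc1cc(Cl)cc(-c2nn(-c3cccc(NC(=O)Nc4cc(C(F)(F)F)cc(C(F)(F)F)c4)c3)cc2-c2ccncc2)c1` gives -2.95% in this assay, the lowest of the three numbers: compound 2 lies within the scatter of it, while compound 1 stands well beyond the scatter. Compound 4 `COc1cc(Cl)cc(-c2nn(-c3cccc(NC(=O)Nc4cccc(C(F)(F)F)c4)c3)cc2-c2ccncc2)c1` has not yet been measured in this assay. It differs from compound 3 in one place: hydrogen in place of trifluoromethyl on an aromatic carbon. Going by the values given here, no step between measured compounds is known here, so the expectation rests only on compounds 2 and 3, which lie within the scatter of each other. The step of a number 13 percentage points higher from compound 3 to compound 4 (beyond the scatter) is therefore expected to be small, at most a modest rise. The estimate for compound 4 is 10%, ranging from -10% to 40%.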

Compound 4, a percentage reported as activity, at one concentration (the size of the read-out at that concentration, not a potency): 6.89%
Compound 4: middle estimate off by 3.1 percentage points, on the high side; measured number inside the range.
By their numbers in this assay, from the lowest: compounds 3, 2 and 4 (each within the scatter of the next); then compound 1.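

In this assay, hydrogen in place of trifluoromethyl on this aromatic carbon gives a number 9.8 percentage points higher from compound 3 to compound 4 (within the scatter), so this position tolerates the loss of that group at the concentration tested. On the carbonyl carbon, (3-(trifluoromethyl)phenyl)amino in place of 3,4-dichlorophenyl gives a number 47.7 percentage points lower from compound 1 to compound 4 (beyond the scatter), showing that this exchange matters far more than the trifluoromethyl change. No measured evidence bears on the cause of either step. From the compounds shown here alone, what an amine or a carboxylic acid would give on the same aromatic carbon remains open. So does whether the same holds at other concentrations.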